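Phenoxy in place of butyl: expectation for compound 3

The source may hold more compounds than are shown below. What is called first, only, known or untested is meant among the compounds shown, and "the series" means these compounds.

Measured compounds:
compound 1 `O=C(Nc1nn[nH]n1)c1cccc(Br)n1` — 48%
compound 2 `CCCCc1cccc(C(=O)Nc2nn[nH]n2)n1` — 18%

In a functional assay on the whole organism for inhibition, with Rattus norvegicus as the target, at a dose of 10 mg/kg by the oral route (a lower number here means a weaker effect, a higher number a stronger effect of the compound at the dose given), compound 1 gives 48%, while compound 2 gives 18%. Going by the values given here, compound 2 thus stands lowest of the two numbers known so far; the only measured step, a number 30 percentage points lower from compound 1 to compound 2 (beyond the scatter), lies beyond the scatter and went downward when butyl replaced bromo on the aromatic carbon.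

Compound 3 `O=C(Nc1nn[nH]n1)c1cccc(Oc2ccccc2)n1` is the next member and has not yet been measured. It differs from compound 2 in one place: phenoxy in place of butyl on an aromatic carbon.

Among the compounds with values here, the single measured step concerns a different pair of groups, bromo and butyl, and neither group is the phenoxy entering here, so it bears on the present change only loosely. Nothing has been measured for a phenoxy on this carbon. With so little to go on, no step beyond the scatter in either direction is expected with confidence; the estimate stays near the value of compound 2 with a wide range. Compound 3 is expected to give 22%, between 5% and 45%. The step of a number 4 percentage points higher from compound 2 to compound 3 (within the scatter) is estimated to be small.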

Compound 3, a percentage reported as inhibition, in the whole organism at one dose (the size of the read-out at that dose, not a potency): 0%
Estimate against measurement, compound 3: 22 percentage points above; the measured number lies below the stated range.
By their numbers in this assay, from the lowest: compound 3; then compound 2; then compound 1.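

In this assay this position proves sensitive to more than the change from bromo to butyl: with phenoxy on the aromatic carbon next to the ring nitrogen, the series shows a number 18 percentage points lower from compound 2 to compound 3 (beyond the scatter) and compound 3 reads 0% at the dose given. Measured against the bromo of compound 1, the same group gives a number 48 percentage points lower from compound 1 to compound 3 (beyond the scatter) so both replacements of bromo shown here, butyl and phenoxy, go downward, and neither the chain nor the oxygen-linked aromatic ring keeps the read-out of compound 1. No measured property of these groups is available to account for the order of the three compounds.

The compounds shown leave open whether the loss with phenoxy belongs to the aromatic ring or to the oxygen link, a question that a directly attached phenyl or a butoxy group on the same carbon would help to separate. They also leave open whether any group at this position matches or exceeds bromo, for example chloro, methoxy or an amine, and whether the order of the three compounds would hold at another dose.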